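A Pyrrolidine Replaces the Anilino Group on the Core

A few compounds are considered here, and "the series" means these few. Any claim that something is new, unique, unknown or untested is made for them only; others in the source may bear on it.

Three compounds share one core and differ only in the group on the aromatic ring of an anilino substituent. Compound 1 `CCCc1ccc(NC2=CC(=O)c3c(nc4n3[C@H]3OC[C@@H](O)[C@H]3OC4)C2=O)cc1` carries a propyl on that aromatic carbon, compound 2 `COc1ccc(NC2=CC(=O)c3c(nc4n3[C@H]3OC[C@@H](O)[C@H]3OC4)C2=O)cc1` a methoxy, and compound 3 `CCOc1ccc(NC2=CC(=O)c3c(nc4n3[C@H]3OC[C@@H](O)[C@H]3OC4)C2=O)cc1` an ethoxy. In a functional assay on ECa-109 cells for inhibition, with ECa-109 cell line (Homo sapiens) as the target, read by sulforhodamine B assay (on this read-out higher numbers stand for weaker inhibition and lower numbers for stronger inhibition), compound 1 gives > 4000 nM, which is a limit of the assay and not a number. Compound 3 gives > 4000 nM, again a limit rather than a number. Among the measured compounds shown here, compound 2 gives 3410 nM, the only true number among the three. The step of an at least 1.1-fold lower number from compound 1 to compound 2 (0.06 log units; that floor lies within the scatter) and the step of an at least 1.1-fold higher number from compound 2 to compound 3 (0.06 log units; that floor lies within the scatter) both lie within the scatter, and a step that the two limits leave unreadable from compound 1 to compound 3.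

Compound 4 `O=C1C(N2CCCC2)=CC(=O)c2c1nc1n2[C@H]2OC[C@@H](O)[C@H]2OC1` has not yet been measured. Compared with compound 2 it shows (pyrrolidin-1-yl in place of (4-methoxyphenyl)amino on a double-bonded ring carbon). For the measured compounds named here, none of the measured steps touches the amine itself; each only swaps the group on the aromatic ring, so none of them bears directly on this change. With no guide from the measured steps, no step beyond the scatter is expected in either direction, but the range must stay wide. Compound 4 is therefore estimated at 4000 nM, between 1500 nM and 12000 nM, which corresponds to an expected step of a 1.2-fold higher number from compound 2 to compound 4 (0.07 log units; within the scatter).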

Compound 4, half-maximal inhibitory concentration: > 16000 nM
Compound 4 was reported as a limit; the forecaster's own chance of this, stated with the estimate: 55%; at least 4.0-fold (0.60 log units) between middle value and limit.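

In this assay, putting pyrrolidin-1-yl in place of (4-methoxyphenyl)amino on the double-bonded ring carbon gives an at least 4.6-fold higher number from compound 2 to compound 4 (0.67 log units; beyond the scatter), so inhibition of the cells becomes weaker. The earlier compounds shown here changed only the group on the aromatic ring of the anilino substituent and gave no step readable beyond the scatter, whereas replacing the whole substituent at this position does, which shows that the position is sensitive to what is attached there. The figure for compound 4 is a limit and not a number, so the step gives only a floor and the true size of the loss stays unknown: the limit of > 16000 nM in this assay, at which 1 of the 4 values shown sits.

This single change removes the aromatic ring and the hydrogen-bond donor together and also swaps a larger substituent for a smaller one, so the compounds shown cannot say which of these differences matters. A cyclohexylamino group would keep the amine hydrogen without the aromatic ring, and an N-methyl-N-phenylamino group would keep the aromatic ring without that hydrogen, so either could begin to separate these differences.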